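A few compounds are considered here, and "the series" means these few. Any claim that something is new, unique, unknown or untested is made for them only; others in the source may bear on it.

Measured compounds:
Compound 1 `COc1ccc(NNS(=O)(=O)c2ccc(NC(C)=O)cc2)cc1`: 254 nM
Compound 2 `CC(=O)Nc1ccc(S(=O)(=O)NNc2ccc(Cl)cc2)cc1`: 155 nM

Among the measured compounds shown here, in an assay for inhibition of Indoleamine 2,3-dioxygenase 1 (Homo sapiens), read by spectrophotometry, with stated times of 1 h and 4 h (on this read-out lower numbers stand for stronger inhibition and higher numbers for weaker inhibition), compound 2 gives 155 nM; its only neighbour is compound 1, and the step from compound 1 to compound 2 is a 1.6-fold lower number from compound 1 to compound 2 (0.21 log units; within the scatter). Compound 3 `CC(=O)Nc1ccc(S(=O)(=O)NNc2ccc(Br)cc2)cc1` differs from compound 2 by bromo in place of chloro on an aromatic carbon. For the measured compounds named here, the one measured step, an exchange of groups at the same aromatic carbon, stayed within the scatter, so no step beyond the scatter is expected in this assay for the exchange of one halogen for another. Compound 3 is therefore estimated at 140 nM, with a range of 60 nM to 330 nM, which is an expected step of a 1.1-fold lower number from compound 2 to compound 3 (0.04 log units; within the scatter).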

Compound 3, half-maximal inhibitory concentration: 130 nM
The estimate for compound 3 lay 1.1-fold (0.03 log units) above the measured number, within the range that was stated.
By their numbers in this assay, from the lowest: compounds 3, 2 and 1 (each within the scatter of the next).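

Bromo in place of chloro gives a 1.2-fold lower number from compound 2 to compound 3 (0.08 log units; within the scatter) in this assay, so the two halogens on this aromatic carbon, para to a large group, cannot be told apart. Bromo in place of methoxy gives a 2.0-fold lower number from compound 1 to compound 3 (0.29 log units; within the scatter), which means that the three groups now seen at this place all lie within the scatter of one another. Nothing available here bears on why these numbers stay so close.

Going by these compounds, it remains open whether a group of another kind on this carbon, such as an amine or a carboxylic acid, would shift the number beyond the scatter.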